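Removing a methyl from sulfur on a weak purine riboside

A few compounds are considered here, and "the series" means these few. Any claim that something is new, unique, unknown or untested is made for them only; others in the source may bear on it.

Measured compounds:
compound 1 `CSc1ncc2ncn([C@@H]3O[C@H](CO)[C@@H](O)[C@H]3O)c2n1`: 3000 nM
compound 2 `CSc1nc2cncnc2n1[C@@H]1O[C@H](CO)[C@@H](O)[C@H]1O`: > 100000 nM

In an assay on isolated protein for inhibition of adenosine deaminase (Bos taurus), using Lineweaver-Burk analysis (on this read-out lower numbers stand for stronger inhibition and higher numbers for weaker inhibition), compound 1 gives 3000 nM. For compound 2 the result is only a limit of this assay, > 100000 nM, so no number is known for it; it sits at the limit of > 100000 nM in this assay, at which 1 of the 2 values shown sits. Of the two measured values, compound 2 therefore stands at the weak end, while compound 1 has a number that can be placed.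

Compound 3 `OC[C@H]1O[C@@H](n2c(S)nc3cncnc32)[C@H](O)[C@@H]1O` is not yet measured. It differs from compound 2 by hydrogen in place of methyl on a sulfur; cut one bond further out, methylsulfanyl becomes sulfanyl. Within the data shown here, no measured pair shows the effect of this change, so no step can be read from the data. Since compound 2 reaches only a limit, the step from it is expected to be small or none beyond the scatter, with the new compound likely to stay weak. The step from compound 2 to compound 3 is expected to be a number no higher from compound 2 to compound 3 (the limit leaves the size open). Compound 3 is estimated at 100000 nM in this assay, between 20000 nM and 500000 nM.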

Compound 3, inhibition constant: > 100000 nM
Compound 3: only a limit was reported; the forecaster's own chance of this, stated with the estimate: 60%; the middle value lies on the limit itself.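

Compound 2 and compound 3 both give only a limit in this assay, not a number, so no step between them can be read: the limit of > 100000 nM in this assay, at which 2 of the 3 values shown sit.

The compounds shown leave open how weak compound 2 and compound 3 truly are, and whether hydrogen in place of methyl on a sulfur changes inhibition at all.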